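The compounds below may be only part of what the source reports. "The series", "measured", "known", "first", "only" and "open" are said of these compounds alone.

Measured compounds:
compound 1 `COC(=O)c1c(Cc2ccccc2[N+](=O)[O-])c(C)nn1-c1nc(-c2ccc(Cl)c(Cl)c2)c(SC(C)C)s1`, 93000 nM
compound 2 `Cc1nn(-c2nc(-c3ccc(Cl)c(Cl)c3)c(SC(C)C)s2)c(C(=O)O)c1Cc1ccccc1[N+](=O)[O-]`, 20000 nM

In a functional assay on BJAB cells (Homo sapiens) for antiproliferative activity, with a stated time of 4 days (a lower number here means that less compound is needed, a higher number that more compound is needed for the effect), compound 1 gives 93000 nM, the higher of the two numbers, while compound 2 gives 20000 nM. Within the data shown here, the only measured step, a 4.7-fold lower number from compound 1 to compound 2 (0.67 log units; beyond the scatter), concerns the group on an oxygen next to a carbonyl group and not the part of the shared core that changes here. Compound 3 `COC(=O)c1c(Cc2ccccc2[N+](=O)[O-])c(C)nn1-c1nc(-c2ccc(Cl)c(Cl)c2)cs1` differs from compound 1 by hydrogen in place of isopropylsulfanyl on an aromatic carbon. Among the measured compounds shown here, no measured step touches this position, so the data give no guide to the size or direction of a step in this assay. The estimate for compound 3 is therefore kept close to the value of compound 1, with a wide range that allows a step in either direction beyond the scatter. Compound 3 is expected to give 100000 nM (range 30000 nM to 300000 nM), which means an expected 1.1-fold higher number from compound 1 to compound 3 (0.03 log units; within the scatter).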

Compound 3, half-maximal effective concentration: 377000 nM
For compound 3 the middle estimate is 3.8-fold (0.58 log units) below the measured one; the measured number lies above the stated range.
By their numbers in this assay, from the lowest: compound 2; then compound 1; then compound 3.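

Replacing isopropylsulfanyl with hydrogen on this aromatic carbon of the five-membered ring gives a 4.1-fold higher number from compound 1 to compound 3 (0.61 log units; beyond the scatter) in this assay. This position, which the earlier step did not touch, therefore matters for the number: with the group present, less compound is needed for the effect, and the direction of the change is now known for this one replacement. The information available offers no measured explanation for the step.

The compounds shown leave open whether a longer chain on the sulfur, or an amine or a methoxy group on this aromatic carbon, would lower the number further or raise it. They also leave open whether the loss of isopropylsulfanyl would have a similar effect on the carboxylic acid, compound 2.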